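The source may hold more compounds than are shown below. What is called first, only, known or untested is meant among the compounds shown, and "the series" means these compounds.

Measured so far in a functional assay on A498 cells (Homo sapiens) for cytotoxicity, read by sulforhodamine B assay, with a stated time of 48 h; a lower number here means a stronger inhibitor of growth, a higher number a weaker inhibitor of growth:
compound 1 `ClCc1ccccc1Cn1cnc2c(Cl)nc(Cl)nc21` gives 2400 nM
compound 2 `ClCc1cccc(Cn2cnc3c(Cl)nc(Cl)nc32)c1` gives 2390 nM
compound 3 `Nc1nc(Cl)c2ncn(Cc3ccccc3CCl)c2n1` gives 20400 nM

Compound 1 and compound 2 have the same atoms joined differently; how their two cores differ is not broken down here, and their values in this assay lie within the scatter of each other. Compound 3 differs from compound 1 by one change, (amino in place of chloro on an aromatic carbon), and that change made an 8.5-fold higher number from compound 1 to compound 3 (0.93 log units; beyond the scatter). Compound 4 `Nc1nc(Cl)c2ncn(Cc3cccc(CCl)c3)c2n1` is not yet measured; it stands to compound 2 as compound 3 stands to compound 1, through (amino in place of chloro on an aromatic carbon), the same change at the same place. The change is the same, and compound 2 gives 2390 nM within the scatter of compound 1, so the step in this assay is expected to resemble the earlier one. That step is expected to be an 8.4-fold higher number from compound 2 to compound 4 (0.92 log units; beyond the scatter). On that basis compound 4 is expected to give about 20000 nM, most likely between 7000 nM and 60000 nM.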

Compound 4, concentration for 50% growth inhibition: 25100 nM
Compound 4: middle estimate off by 1.3-fold (0.10 log units), on the low side; low and high end bracket the measured number.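

In this assay, amino in place of chloro on an aromatic carbon gave an 11-fold higher number from compound 2 to compound 4 (1.02 log units; beyond the scatter), and the change carried from one core to the other with much the same size: the same change on two cores in this assay, an 8.5-fold higher number (0.93 log units; beyond the scatter) from compound 1 to compound 3 and an 11-fold higher number (1.02 log units; beyond the scatter) from compound 2 to compound 4, 1.2-fold (0.09 log units) apart, within the scatter of two such steps

This agreement rests on just two pairs of compounds in a single cell assay, and the two cores have the same atoms joined differently. It does not show why the change raises the number, nor whether it would do the same on a core outside this series.

The compounds shown carry only chloro or amino at this place, so the outcome with a methoxy group or a dimethylamino group there remains open. All four also carry a chloromethyl group, which leaves open how a hydroxymethyl group in its place would read.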